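A few compounds are considered here, and "the series" means these few. Any claim that something is new, unique, unknown or untested is made for them only; others in the source may bear on it.

Measured so far:
compound 1, `O=C(CCCCc1ccc(O)c(O)c1)CCc1ccc(O)c(O)c1`, in a functional assay on RAW264.7 cells (Mus musculus) for inhibition, read by Griess assay, with a stated time of 20 h (a higher number here means a weaker inhibitor, a lower number a stronger inhibitor), compound 1 gives 2600 nM
compound 2, `Oc1ccc(CCCC[C@@H](O)CCc2ccc(O)c(O)c2)cc1O`, in this assay compound 2 gives 5200 nM

Compound 1 and compound 2 give numbers that lie within the usual scatter of each other, so neither stands apart. Compound 3, `O=C(CCc1ccc(O)c(O)c1)C[C@@H](O)CCc1ccc(O)c(O)c1`, differs from compound 1 by hydroxy in place of hydrogen on a saturated chain carbon bound to two saturated chain carbons. Among the compounds with values here, no measured pair differs in this one place alone, so there is no measured step to lean on; in this assay this change is expected to shift the number by no more than the scatter, in either direction. For compound 3 the estimated value is 3500 nM, within a range from 1500 nM to 8000 nM. That estimate amounts to an expected step of a 1.3-fold higher number from compound 1 to compound 3 (0.13 log units; within the scatter).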

Compound 3, half-maximal inhibitory concentration: 17800 nM
For compound 3 the middle estimate is 5.1-fold (0.71 log units) below the measured one; the whole stated range lies below it.
By their numbers in this assay, from the lowest: compounds 1 and 2 (each within the scatter of the next); then compound 3.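

Hydroxy in place of hydrogen on a saturated chain carbon bound to two saturated chain carbons gives a 6.8-fold higher number from compound 1 to compound 3 (0.84 log units; beyond the scatter) in this assay and so makes the inhibitor weaker. This position is therefore sensitive to the change, and this is the first difference among these compounds to exceed the scatter. Nothing available explains the loss. The compounds shown leave open whether a methoxy group or an amine on this same carbon would also weaken inhibition.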